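The source may hold more compounds than are shown below. What is called first, only, known or untested is meant among the compounds shown, and "the series" means these compounds.

Measured so far:
- compound 1 `Oc1ccccc1N1CCN(CC(O)COc2ccc(O)c3ccccc23)CC1`: 37400 nM
- compound 2 `Oc1ccccc1N1CCN(CC(O)COc2cccc3ccccc23)CC1`: 22200 nM

In an ADME assay on PNT1A cells (Homo sapiens) for cytotoxicity, read by MTT assay, with a stated time of 48 h (a higher number here means a weaker inhibitor, a lower number a stronger inhibitor), compound 1 gives 37400 nM and stands highest of the two numbers, while compound 2 gives 22200 nM; the step of a 1.7-fold lower number from compound 1 to compound 2 (0.23 log units; within the scatter) lies within the scatter. Compound 3 `COc1ccccc1N1CCN(CC(O)COc2ccc(O)c3ccccc23)CC1` differs from compound 1 by methyl in place of hydrogen on an oxygen on an aromatic ring, a methyl in place of hydrogen on an oxygen on an aromatic ring. Within the data shown here, no measured step touches that oxygen; the one step known, a 1.7-fold lower number from compound 1 to compound 2 (0.23 log units; within the scatter), concerns a hydroxy on the naphthalene side and was itself within the scatter. No change beyond the scatter is therefore expected in this assay. Compound 3 is expected to give about 35000 nM, between 15000 nM and 80000 nM, a step of a 1.1-fold lower number from compound 1 to compound 3 (0.03 log units; within the scatter).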

Compound 3, half-maximal inhibitory concentration: 34900 nM
For compound 3 the middle estimate is 1.0-fold (0.00 log units) above the measured one, within the range that was stated.
By their numbers in this assay, from the lowest: compounds 2, 3 and 1 (each within the scatter of the next).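

In this assay, the step, a 1.1-fold lower number from compound 1 to compound 3 (0.03 log units; within the scatter), is the only one shown at this oxygen on an aromatic ring, and it lies within the scatter. On the core of compound 1, 2-hydroxyphenyl and 2-methoxyphenyl therefore cannot be told apart here, which the earlier step, at another place, could not show. No evidence on hand gives a reason for this result. As far as these compounds go, it remains open whether a longer chain on this oxygen, or an amine in place of the hydroxy, would also stay within the scatter. From the compounds shown here alone, it is also open whether hydroxy to methoxy reads the same on the core of compound 2.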